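Three fluorines on a compound at the limit

This account rests on a few compounds, and the source may have more. Where it says the series, first, only, none or still open, it means among the compounds named here.

Compound 1 `C=C[C@@](C)(/C=C/c1ccc(OCc2ccccc2)cc1)CCC=C(C)C` gives > 26000 nM as a limit
Compound 2 `C=C[C@@](C)(/C=C/c1ccc(Nc2ccc(F)cc2)cc1)CCC=C(C)C` gives > 26000 nM as a limit

Both entries come from a functional assay on Raji cells (Homo sapiens) for cytotoxicity, with a stated time of 72 h (a lower number here means that less compound is needed, a higher number that more compound is needed for the effect), and neither is a number. For compound 2 the result > 26000 nM is a limit of the assay, so its standing is known only as a limit. The whole evidence so far is the limit of > 26000 nM in this assay, at which 2 of the 2 values shown sit, and no measured number anchors the series.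

Compound 3 `C=C[C@@](C)(/C=C/c1ccc(Nc2cc(F)c(F)c(F)c2)cc1)CCC=C(C)C` differs from compound 2 in one group, with 3,4,5-trifluorophenyl in place of 4-fluorophenyl on a nitrogen on an aromatic ring and the shared core stays the same.

Among the compounds with values here, the only measured step is a step that the two limits leave unreadable from compound 1 to compound 2 and so no size carries over. No change beyond the scatter is therefore expected in this assay in either direction. Written as a step, the estimate is a step that the limit leaves unreadable from compound 2 to compound 3 as an expectation only. For compound 3 the estimated value is 30000 nM with an expected range from 13000 nM to 70000 nM. A limit in place of a number would be no surprise for compound 3 either.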

Compound 3, half-maximal effective concentration: > 26000 nM
Compound 3 was reported as a limit; the forecaster's own chance of this, stated with the estimate: 75%; the middle value does not contradict the limit.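

Within the data shown here, compound 2 and compound 3 are both reported only as limits in this assay, so putting 3,4,5-trifluorophenyl in place of 4-fluorophenyl gives no step that can be read. The compounds shown leave open what concentration any of them would need for the effect, and whether any group at this place would give a measured number: the limit of > 26000 nM in this assay, at which 3 of the 3 values shown sit.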